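This account rests on a few compounds, and the source may have more. Where it says the series, first, only, none or still open, it means among the compounds named here.

Of the compounds shown here, three have been measured in a physicochemical assay for lipophilicity; a higher number here means a more lipophilic compound, a lower number a more polar compound. Compound 1 `Cc1ccc(C(=O)N/N=C/c2cccc([N+](=O)[O-])c2)cc1` gives 3.85. Compound 2 `Nc1ccc(C(=O)N/N=C/c2cccc([N+](=O)[O-])c2)cc1` differs from it in one place, (amino in place of methyl on an aromatic carbon), and in this assay compound 2 gives 2.6. The step between them, a number 1.25 log units lower from compound 1 to compound 2 (beyond the scatter), is one of the larger changes in the set. Compound 3 `COc1ccc(/C=N/NC(=O)c2ccc(C)cc2)cc1OC` is built on a different core; how that core differs from the core of compound 1 is not broken down here. In this assay compound 3 gives 3.39, which puts it between the other two.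

Compound 4 `COc1ccc(/C=N/NC(=O)c2ccc(N)cc2)cc1OC` has not yet been measured. It is related to compound 3 exactly as compound 2 is related to compound 1: amino in place of methyl on an aromatic carbon. Since the two "place" descriptions agree word for word, this is the same change made on a second core. Going by the values given here, the only guide to its size is the step already seen, because a number 1.25 log units lower from compound 1 to compound 2 (beyond the scatter) was recorded on the first core under the same conditions. On that basis the step from compound 3 to compound 4 is expected to be about as large, a number 1.25 log units lower from compound 3 to compound 4 (beyond the scatter), with the understanding that a change can behave somewhat differently on a different core. Compound 4 is therefore estimated to give 2.14 in this assay, most likely falling between 1.75 and 2.55.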

Compound 4, partition coefficient: 2.14
Beside the measured number, compound 4's estimate shows no gap at the digits printed; low and high end bracket the measured number.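

In this assay, the replacement of methyl by amino on the second core gives a number 1.25 log units lower from compound 3 to compound 4 (beyond the scatter) and on the first core it gave a number 1.25 log units lower from compound 1 to compound 2 (beyond the scatter), so the change has the same size on both cores at the digits printed, and neither pair goes against this. That makes the step from 4-methylphenyl to 4-aminophenyl transferable across these two cores, but two pairs are a small sample and show nothing about how the same change would behave on any further core. Nothing given here explains why the step has this size or why it repeats, so the agreement stands as an observation without a reason.

The compounds shown leave open whether a hydroxyl group, a carboxylic acid or a longer chain such as ethyl, placed where the amino group stands, would also give one matching step on both cores. They also leave open whether a dimethylamino group would follow the amino group closely or would behave differently from one core to the other.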